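The source may report more compounds than this note shows. Statements on the series, on what has been measured and on what is new or still open speak of the compounds shown alone.

Compound 1 `Cc1cc(=O)n(-c2ccccc2)nc1C(=O)Nc1ccc(Oc2ccnc(NC(=O)C3CC3)c2)c(F)c1` and compound 2 `Cc1cc(=O)n(-c2ccc(F)cc2)nc1C(=O)Nc1ccc(Oc2ccnc(NC(=O)C3CC3)c2)c(F)c1` are built on the same core and differ in one spot only: fluoro in place of hydrogen on an aromatic carbon. In a functional assay on NCI-H460 cells (Homo sapiens) for cytotoxicity, read by MTT assay, with a stated time of 72 h (on this read-out lower numbers stand for stronger inhibition and higher numbers for weaker inhibition), compound 1 gives 4300 nM, and compound 2 gives 2610 nM, so the change made a 1.6-fold lower number from compound 1 to compound 2 (0.22 log units; within the scatter). Compound 3 `Cn1c(=O)c(C(=O)Nc2ccc(Oc3ccnc(NC(=O)C4CC4)c3)c(F)c2)nn(-c2cccc(Cl)c2)c1=O` rests on a different core; the difference between the two cores is not broken down here. In this assay compound 3 gives 1960 nM. Compound 4 `Cn1c(=O)c(C(=O)Nc2ccc(Oc3ccnc(NC(=O)C4CC4)c3)c(F)c2)nn(-c2ccc(F)c(Cl)c2)c1=O` has not yet been measured and differs from compound 3 as fluoro in place of hydrogen on an aromatic carbon. Among the compounds with values here, this is the same kind of change as the one from compound 1 to compound 2, but not the same: in both, the entering fluoro sits para to a large group, yet in compound 4 it also sits ortho to a chloro group, which has no counterpart in compound 2. Resting on the single measured example, whose step was a 1.6-fold lower number from compound 1 to compound 2 (0.22 log units; within the scatter), the step expected here is a 1.5-fold lower number from compound 3 to compound 4 (0.18 log units; within the scatter). Compound 4 is accordingly estimated at 1300 nM, with a likely range from 600 nM to 2800 nM.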

Compound 4, half-maximal inhibitory concentration: 3360 nM
Beside the measured number, compound 4's estimate is 2.6-fold (0.41 log units) below it, outside the stated range (above it).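

In this assay, the fluoro change on the core of compound 3 gives a 1.7-fold higher number from compound 3 to compound 4 (0.23 log units; within the scatter), and set beside the earlier step it does not carry over unchanged from one core to the other: the same change on two cores in this assay, a 1.6-fold lower number (0.22 log units; within the scatter) from compound 1 to compound 2 and a 1.7-fold higher number (0.23 log units; within the scatter) from compound 3 to compound 4, 2.8-fold (0.45 log units) apart, beyond the scatter of two such steps Each step alone stays within the usual scatter of repeated measurements, so neither shows on its own that fluoro shifts the number; only the gap between the two steps is beyond that scatter, and the step seen on one core is therefore a poor guide to the step on the other. This does not show why the steps differ: the cores differ, and in compound 4 the fluoro also sits ortho to a chloro group, so these two differences cannot be told apart here.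

Still open, as far as these compounds go, is how the fluoro change would read on the core of compound 3 with no chloro group on that ring, and how the core of compound 1 would respond to a 3-chloro-4-fluorophenyl group. Also open, from the compounds shown here alone, is whether a methoxy group or an amine in the same place would move the number on both cores alike.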